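This account rests on a few compounds, and the source may have more. Where it says the series, first, only, none or still open, it means among the compounds named here.

In an ADME assay for permeability, using PAMPA, at pH 7.4 (a lower number here means that the compound crosses the layer more slowly, a higher number that the compound crosses the layer faster), compound 1 `Cc1[nH]c2ccccc2c(=O)c1Cc1ccccc1` gives 102 10^-6 cm/s and compound 2 `COc1ccc2[nH]c(C)c(Cc3ccccc3)c(=O)c2c1` gives 188 10^-6 cm/s so the two stand within the scatter of each other. Compound 3 `Cc1[nH]c2cccc(Cl)c2c(=O)c1Cc1ccccc1` differs from compound 1 by chloro in place of hydrogen on an aromatic carbon on the shared core. For the measured compounds named here, only one measured step bears on this change, with a different group: methoxy in place of hydrogen on an aromatic carbon gives a 1.8-fold higher number from compound 1 to compound 2 (0.27 log units; within the scatter) as its size. No step beyond the scatter is therefore expected in this assay for the chloro. For compound 3 the estimated step is (a 1.3-fold higher number from compound 1 to compound 3 (0.11 log units; within the scatter)). Compound 3 is estimated at 130 10^-6 cm/s with an expected range from 60 10^-6 cm/s to 260 10^-6 cm/s for the next measurement.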

Compound 3, apparent permeability: 251 10^-6 cm/s
Beside the measured number, compound 3's estimate is 1.9-fold (0.29 log units) below it; the range from low to high includes it.
By their numbers in this assay, from the lowest: compounds 1, 2 and 3 (each within the scatter of the next, the first and the last beyond it).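

In this assay, chloro in place of hydrogen on an aromatic carbon ortho to a fused ring gives the only step shown beyond the scatter (a 2.5-fold higher number from compound 1 to compound 3 (0.39 log units; beyond the scatter)), while the methoxy step at another carbon of the shared core stays within it (a 1.8-fold higher number from compound 1 to compound 2 (0.27 log units; within the scatter)). This carbon therefore tolerates chloro with a higher number, not a lower one. No measurement shown accounts for the size of this step.

Going by these compounds, only chloro stands at this carbon, so whether the step belongs to the group or the position stays open. An amine or a carboxylic acid on the same carbon remains an open case.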